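This account rests on a few compounds, and the source may have more. Where it says the series, first, only, none or still open, it means among the compounds named here.

The series shares the core of compound 1 `CCc1ccccc1N(CC(=O)NCc1ccc(OC)c(OC)c1)S(=O)(=O)c1ccc(C)cc1` and varies the group carried on the saturated chain carbon bound to the amide-type nitrogen. In a functional assay on CHO-K1 cells for antagonist activity at prostaglandin E2 receptor EP1 subtype (Homo sapiens), read by FLIPR and calcium flux (a higher number here means a weaker inhibitor, a lower number a stronger inhibitor), compound 1 gives 282 nM. Compound 2 `CCc1ccccc1N(CC(=O)NCc1ccccc1)S(=O)(=O)c1ccc(C)cc1` gives 224 nM in this assay, and compound 3 `CCc1ccccc1N(CC(=O)NCc1cccc(OC)c1)S(=O)(=O)c1ccc(C)cc1` gives 138 nM in this assay. The step of a 1.3-fold lower number from compound 1 to compound 2 (0.10 log units; within the scatter) is small, as is a 1.6-fold lower number from compound 2 to compound 3 (0.21 log units; within the scatter); only a 2.0-fold lower number from compound 1 to compound 3 (0.31 log units; beyond the scatter) reaches beyond the scatter. Compound 3 thus has the lowest number of the three, clearly apart from compound 1 but not separated from compound 2.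

Compound 4 `CCc1ccccc1N(CC(=O)NCc1cccc(OC(F)(F)F)c1)S(=O)(=O)c1ccc(C)cc1` differs from compound 3 by trifluoromethyl in place of methyl on an oxygen on an aromatic ring. For the measured compounds named here, no measured step touches the group on this oxygen; the two steps that concern the methoxy itself, a 1.6-fold lower number from compound 2 to compound 3 (0.21 log units; within the scatter) and a 2.0-fold lower number from compound 1 to compound 3 (0.31 log units; beyond the scatter), were both small, so changes in this region have so far given only small steps. For compound 4 a step of a 1.1-fold higher number from compound 3 to compound 4 (0.04 log units; within the scatter) in this assay is expected, not beyond the scatter in either direction. The estimate for compound 4 is therefore 150 nM, with a range from 60 nM to 400 nM.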

Compound 4, inhibition constant: 427 nM
Beside the measured number, compound 4's estimate is 2.8-fold (0.45 log units) below it; measured number above the stated range.
By their numbers in this assay, from the lowest: compounds 3, 2, 1 and 4 (each within the scatter of the next, the first and the last beyond it).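

Trifluoromethyl in place of methyl on an oxygen on an aromatic ring gives a step beyond the scatter in this assay (a 3.1-fold higher number from compound 3 to compound 4 (0.49 log units; beyond the scatter)), so the group carried on this oxygen matters, which the earlier compounds, with only methoxy or hydrogen on the aromatic carbons, could not show. The change separates compound 4 only from compound 3: the steps to it from the other two stay within the scatter (a 1.9-fold higher number from compound 2 to compound 4 (0.28 log units; within the scatter); a 1.5-fold higher number from compound 1 to compound 4 (0.18 log units; within the scatter)). The 3-(trifluoromethoxy)phenyl group is thus not separated from the plain phenyl or the 3,4-dimethoxyphenyl group.

Nothing available explains why this exchange gives a step of this size. Open, from the compounds shown here alone, is how the number responds to other groups on this oxygen, such as ethyl, or to a hydroxyl in place of the methoxy.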